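Methoxycarbonyl for Trifluoromethyl, Tried on a Longer Chain

This account rests on a few compounds, and the source may have more. Where it says the series, first, only, none or still open, it means among the compounds named here.

Measured so far in a functional assay on M21 cells (Homo sapiens) for antiproliferative activity, read by sulforhodamine B assay, with a stated time of 48 h; a lower number here means a stronger inhibitor of growth, a higher number a weaker inhibitor of growth:
Compound 1 `NS(=O)(=O)NCC1CCN(c2cc(-c3ccc(C(F)(F)F)cc3)ncn2)CC1` gives 43100 nM.
Compound 2 `COC(=O)c1ccc(-c2cc(N3CCC(CNS(N)(=O)=O)CC3)ncn2)cc1` gives 14100 nM.
Compound 3 `NS(=O)(=O)NCCC1CCN(c2cc(-c3ccc(C(F)(F)F)cc3)ncn2)CC1` gives 34800 nM.

Compound 4 `COC(=O)c1ccc(-c2cc(N3CCC(CCNS(N)(=O)=O)CC3)ncn2)cc1` has not yet been measured. Compound 3 differs from compound 1 by (sulfamoylamino)methyl in place of sulfamoylamino on a saturated chain carbon bound to a saturated ring carbon, and in this assay this amounts to a 1.2-fold lower number from compound 1 to compound 3 (0.09 log units; within the scatter), so the two cores behave almost alike. Compound 2 differs from compound 1 by methoxycarbonyl in place of trifluoromethyl on an aromatic carbon, and that step is a 3.1-fold lower number from compound 1 to compound 2 (0.49 log units; beyond the scatter). Compound 4 differs from compound 3 by methoxycarbonyl in place of trifluoromethyl on an aromatic carbon, the same change in the same place, now on the longer chain. Because the step of a 1.2-fold lower number from compound 1 to compound 3 (0.09 log units; within the scatter) lies within the scatter, the same change is expected to act much as before. Compound 4 is therefore expected to make a similar step, a 3.0-fold lower number from compound 3 to compound 4 (0.48 log units; beyond the scatter). Compound 4 is estimated at 11500 nM in this assay.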

Compound 4, concentration for 50% growth inhibition: 19600 nM
Compound 4: the middle estimate sits 1.7-fold (0.23 log units) below what was measured; the range from low to high includes it.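

In this assay, methoxycarbonyl in place of trifluoromethyl on the longer chain gives a 1.8-fold lower number from compound 3 to compound 4 (0.25 log units; within the scatter) and stays close to the earlier step: the same change on two cores in this assay, a 3.1-fold lower number (0.49 log units; beyond the scatter) from compound 1 to compound 2 and a 1.8-fold lower number (0.25 log units; within the scatter) from compound 3 to compound 4, 1.7-fold (0.24 log units) apart, within the scatter of two such steps.
Lengthening the chain while methoxycarbonyl is present gives a 1.4-fold higher number from compound 2 to compound 4 (0.14 log units; within the scatter) and also matches its partner step: the same change on two cores in this assay, a 1.2-fold lower number (0.09 log units; within the scatter) from compound 1 to compound 3 and a 1.4-fold higher number (0.14 log units; within the scatter) from compound 2 to compound 4, 1.7-fold (0.24 log units) apart, within the scatter of two such steps.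
For the compounds shown here, the change therefore carries from one core to the other with no detectable difference, but this rests on only two pairs and does not show that it would carry to other cores, and the step on the longer chain lies within the scatter, so it shows no clear gain there on its own.

The compounds shown leave open how a carboxylic acid or a nitrile would behave in the same place on the aromatic ring. They also leave open whether a still longer chain would fit the same picture.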